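The source may report more compounds than this note shows. Statements on the series, on what has been measured and on what is new or still open speak of the compounds shown alone.

Working notes on the series. Compound 1 `COc1ccc(OCC(=O)N2CCN(c3ccc(C(F)(F)F)cc3[C@@H](N)CC(C)C)CC2)cc1` has the higher of the two plain numbers in an assay on HEK293 cells for displacement of a labelled ligand from Melanocortin receptor 4 (Homo sapiens); on this read-out higher numbers stand for weaker inhibition and lower numbers for stronger inhibition: compound 1 gives 3800 nM. Its nearest neighbour is compound 2 `CC(C)C[C@H](N)c1cc(C(F)(F)F)ccc1N1CCN(C(=O)CC(C)C(=O)c2ccc(Cl)cc2)CC1`, for which this assay gives 1100 nM; the step of a 3.5-fold lower number from compound 1 to compound 2 (0.54 log units; beyond the scatter) is modest but beyond the scatter, with 1-((4-chlorophenyl)carbonyl)ethyl in place of 4-methoxyphenoxy on a saturated chain carbon bound to a carbonyl carbon. Compound 3 `CC(C)C[C@H](N)c1cc(C(F)(F)F)ccc1N1CCN(C(=O)C(C)Cc2ccc(Cl)c(Cl)c2)CC1` carries two entries in this assay, 120 nM; 1600 nM (2 entries), and the several entries of compound 3 in this assay, 120 nM; 1600 nM (2 entries) shows how far repeated entries of one compound can sit apart here.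

Compound 4 `CC(C)C[C@H](N)c1cc(C(F)(F)F)ccc1N1CCN(C(=O)COc2cccc(Cl)c2)CC1` differs from compound 1 by 3-chlorophenyl in place of 4-methoxyphenyl on an oxygen on a saturated carbon; cut one bond further out, the same difference reads 4-methoxyphenoxy to 3-chlorophenoxy. Within the data shown here, the only measured step that bears on it is the one from compound 1 to compound 2, where a chlorophenyl group also entered in place of 4-methoxyphenoxy and the number fell modestly. A smaller step in the same direction, at or just beyond the scatter, is expected here: a 2.1-fold lower number from compound 1 to compound 4 (0.32 log units; beyond the scatter). For compound 4 the estimate in this assay is 1800 nM, expected to fall between 500 nM and 6000 nM.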

Compound 4, inhibition constant: 2600 nM
Beside the measured number, compound 4's estimate is 1.4-fold (0.16 log units) below it; low and high end bracket the measured number.
By their numbers in this assay, from the lowest: compound 2; then compounds 4 and 1 (each within the scatter of the next).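

In this assay, 3-chlorophenyl in place of 4-methoxyphenyl on an oxygen on a saturated carbon gives a 1.5-fold lower number from compound 1 to compound 4 (0.16 log units; within the scatter) and so does not separate the two compounds, which means that this exchange on the ether oxygen does not reproduce the gain seen with compound 2. The step of a 2.4-fold higher number from compound 2 to compound 4 (0.37 log units; beyond the scatter) shows that, among these compounds, a chlorophenyl group alone does not account for the value of compound 2, since 3-chlorophenoxy in place of 1-((4-chlorophenyl)carbonyl)ethyl costs a modest amount. Steps this small need caution, as repeated entries of one compound can sit far apart here: the several entries of compound 3 in this assay, 120 nM; 1600 nM (2 entries).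

Open, on these data alone, is whether any group on this ether side moves the number well beyond the scatter. An amine or a carboxylic acid on the phenoxy ring, or a longer chain before the ether oxygen, would test this.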